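The source may hold more compounds than are shown below. What is called first, only, known or untested is meant among the compounds shown, and "the series" means these compounds.

Measured so far:
compound 1 `Cc1c(OCCCCOc2ccccc2C(=O)O)ccc(C(=O)CC2CCCC2)c1O`: 32.9%
compound 2 `COc1ccc(C(=O)O)cc1OCCCCOc1ccc(C(=O)CC2CCCC2)c(O)c1C`: 67.6%

Within the data shown here, of the two numbers in an assay on HEK293 cells for positive allosteric modulation of metabotropic glutamate receptor 3 (Rattus norvegicus), read by thallium flux, with a stated time of 2.5 min (on this read-out lower numbers stand for smaller maximal responses and higher numbers for larger maximal responses), compound 2 holds the higher one; the single measured step, a number 34.7 percentage points higher from compound 1 to compound 2 (beyond the scatter), lies well beyond the scatter, so compound 2 stands clearly above compound 1 on this read-out.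

Compound 3 `Cc1ccc(C(=O)O)cc1OCCCCOc1ccc(C(=O)CC2CCCC2)c(O)c1C` keeps the core of compound 2 and differs from it in one place: methyl in place of methoxy on an aromatic carbon. Among the measured compounds shown here, the only measured step, from compound 1 to compound 2, exchanged the whole aryl group on the oxygen and is large, but it does not test a methoxy against a methyl on an otherwise unchanged 5-carboxyphenyl, so no measured step bears directly on the change to compound 3. With nothing to point either way, the expected step in this assay for compound 3 is a number 5.6 percentage points lower from compound 2 to compound 3 (within the scatter), that is, none beyond the scatter. Compound 3 is therefore estimated at 62% in this assay, with a range from 42% to 82% that allows for a modest shift in either direction.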

Compound 3, largest response reached (reported as percent of maximum), in percent of the reference or control that the assay uses: 26.9%
For compound 3 the middle estimate is 35.1 percentage points above the measured one; measured number below the stated range.
By their numbers in this assay, from the lowest: compounds 3 and 1 (each within the scatter of the next); then compound 2.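

In this assay, the methoxy ortho to a large group and para to a carboxy group proves to count on its own: methyl in its place brings a number 40.7 percentage points lower from compound 2 to compound 3 (beyond the scatter) and this large step changes that single group only, whereas the earlier step exchanged the whole aryl group. Moving from 2-carboxyphenyl to 5-carboxy-2-methylphenyl on the oxygen gives a number 6 percentage points lower from compound 1 to compound 3 (within the scatter) and so does not separate these two groups on this read-out, which means that among the three compounds the high maximal response appears only where the methoxy is present, and the 5-carboxy arrangement with methyl does not carry it. No available evidence bears on the reason for this difference between methoxy and methyl.

The compounds shown leave open whether an ethoxy, a hydroxy or a chlorine at this place would hold the response of the methoxy or fall to that of the methyl. They also leave open whether a methoxy would bring the same large step with the carboxylic acid elsewhere on the ring or with a longer chain between the two oxygens.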